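Three aryl variants on a shared core, and a fourth

The compounds below may be only part of what the source reports. "The series", "measured", "known", "first", "only" and "open" are said of these compounds alone.

Measured compounds:
compound 1, `N#CC1=C(N)OC(c2c[nH]c3ccccc23)=C(C#N)C1c1ccc(F)cc1`: 26.7%
compound 2, `N#CC1=C(N)OC(c2c[nH]c3ccccc23)=C(C#N)C1c1ccccc1Cl`: 21.4%
compound 3, `Cc1ccc(C2C(C#N)=C(N)OC(c3c[nH]c4ccccc34)=C2C#N)cc1`: 8.5%

In a functional assay, tested at 400 ug/mL (on this read-out higher numbers stand for a stronger effect at the one concentration tested and lower numbers for a weaker effect), compound 1 gives 26.7%, the highest of the three numbers, though its gap to compound 2 is within the scatter and only its gap to compound 3 is beyond it. The unmeasured compound 4 is `COc1ccc(C2C(C#N)=C(N)OC(c3c[nH]c4ccccc34)=C2C#N)cc1OC`. It differs from compound 1 in one place: 3,4-dimethoxyphenyl in place of 4-fluorophenyl on a saturated ring carbon.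

Going by the values given here, three measured steps bear on this change, since each exchanges the group on the same saturated ring carbon. The step of a number 5.3 percentage points lower from compound 1 to compound 2 (within the scatter) was within the scatter; the steps of a number 18.2 percentage points lower from compound 1 to compound 3 (beyond the scatter) and a number 12.9 percentage points lower from compound 2 to compound 3 (beyond the scatter) were modest and beyond it. Every exchange at this position has so far lowered the number, with compound 1 the highest point. A modest downward step is therefore expected for compound 4, though the new group is unlike any tried. Compound 4 is estimated to give 16%, with a range from 6% to 28%. This estimate means an expected step of a number 10.7 percentage points lower from compound 1 to compound 4 (beyond the scatter).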

Compound 4, a percentage reported as activity, at one concentration (the size of the read-out at that concentration, not a potency): 28.1%
Compound 4: the middle estimate sits 12.1 percentage points below what was measured; measured number above the stated range.
By their numbers in this assay, from the lowest: compound 3; then compounds 2, 1 and 4 (each within the scatter of the next).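

In this assay, the 3,4-dimethoxyphenyl group on this saturated ring carbon does not continue the downward run seen so far, giving a number 1.4 percentage points higher from compound 1 to compound 4 (within the scatter) and a number 6.7 percentage points higher from compound 2 to compound 4 (within the scatter), so this position accepts an aryl group with two hydrogen-bond acceptors without a step beyond the scatter. Going by these compounds alone, with a number 19.6 percentage points higher from compound 3 to compound 4 (beyond the scatter), compound 3, with its 4-methylphenyl group, is now the one compound set apart from all the others, while compounds 1, 2 and 4 cannot be told apart on this read-out. Nothing available accounts for these differences among the aryl groups.

Going by these compounds, whether a single methoxy group, or an amine or a carboxylic acid on the phenyl ring, would stay level with compound 4 or fall towards compound 3 remains open. So does whether a longer chain could replace the aryl group at this carbon.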